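Bromo in Place of Methoxy on an Aromatic Carbon

This account rests on a few compounds, and the source may have more. Where it says the series, first, only, none or still open, it means among the compounds named here.

Among the measured compounds shown here, in a functional assay on HeLa cells (Homo sapiens) for cytotoxicity, read by MTT assay, with a stated time of 72 h (a lower number here means a stronger inhibitor, a higher number a weaker inhibitor), compound 1 (`O=C(/C=C/c1ccc([N+](=O)[O-])cc1)Nc1cc2c(Nc3ccc(F)c(Cl)c3)ncnc2cc1O[C@H]1CCOC1`) gives 27400 nM and compound 2 (`COc1ccc(/C=C/C(=O)Nc2cc3c(Nc4ccc(F)c(Cl)c4)ncnc3cc2O[C@H]2CCOC2)cc1`) stands within the scatter of it at 34600 nM on the only two numbers available. Compound 3 (`O=C(/C=C/c1ccc(Br)cc1)Nc1cc2c(Nc3ccc(F)c(Cl)c3)ncnc2cc1O[C@H]1CCOC1`) differs from compound 2 by bromo in place of methoxy on an aromatic carbon, para to a large group (bromo in place of methoxy on an aromatic carbon). For the measured compounds named here, the one measured step at that place is a 1.3-fold higher number from compound 1 to compound 2 (0.10 log units; within the scatter) with methoxy in place of nitro, so no shift beyond the scatter is expected. The estimated move is a 1.2-fold lower number from compound 2 to compound 3 (0.06 log units; within the scatter) on this single precedent. Compound 3 is estimated at 30000 nM (range 15000 nM to 60000 nM).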

Compound 3, half-maximal inhibitory concentration: 27500 nM
The estimate for compound 3 lay 1.1-fold (0.04 log units) above the measured number; measured number inside the range.
By their numbers in this assay, from the lowest: compounds 1, 3 and 2 (each within the scatter of the next).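

In this assay, bromo in place of methoxy gives a 1.3-fold lower number from compound 2 to compound 3 (0.10 log units; within the scatter), and bromo in place of nitro gives a 1.0-fold higher number from compound 1 to compound 3 (0.00 log units; within the scatter). With a third group now measured on this aromatic carbon, para to a large group, nitro, methoxy and bromo all stand within the scatter of one another, so this position does not yet separate any of these groups. Nothing available offers an explanation for this result. The compounds shown leave open whether an amine, a carboxylic acid or a longer chain here would shift the number beyond the scatter.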